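The source may report more compounds than this note shows. Statements on the series, on what has been measured and on what is new or still open speak of the compounds shown alone.

In a physicochemical assay for solubility, at pH 7.4 (on this read-out higher numbers stand for higher solubility and lower numbers for lower solubility), compound 1 `Cc1c2c(n3c1CCN(C(=O)[C@@H](N)C(C)C)C[C@@H](C)[C@H](C)Nc1cc-3ccc1C(N)=O)CC(C)(C)CC2=O` gives > 100 ug/mL, which is a limit and not a number. Compound 2 `Cc1c2c(n3c1CCN(C(=O)C(C)(C)N)C[C@@H](C)[C@H](C)Nc1cc-3ccc1C(N)=O)CC(C)(C)CC2=O` gives > 100 ug/mL, again only a limit. The picture so far is the limit of > 100 ug/mL in this assay, at which 2 of the 2 values shown sit, and a step that the two limits leave unreadable from compound 1 to compound 2 offers no size to carry forward. Compound 3 `Cc1c2c(n3c1CCN(C(=O)[C@@H](O)C(C)C)C[C@@H](C)[C@H](C)Nc1cc-3ccc1C(N)=O)CC(C)(C)CC2=O` differs from compound 2 as follows: 1-hydroxy-2-methylpropyl in place of 1-amino-1-methylethyl on a carbonyl carbon. This puts 1-hydroxy-2-methylpropyl in place of 1-amino-1-methylethyl on a carbonyl carbon. Among the compounds with values here, compound 3 has no 1-amino group, and the only guide is compound 2 with its limit > 100 ug/mL, so a lower reading of uncertain size is expected. The expected change is an at least 2.5-fold lower number from compound 2 to compound 3 (0.39 log units; beyond the scatter). For compound 3 the estimate is 40 ug/mL, with an expected range from 8 ug/mL to 150 ug/mL.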

Compound 3, solubility: 30 ug/mL
Estimate against measurement, compound 3: 1.3-fold (0.12 log units) above; the range from low to high includes it.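

In this assay, hydroxy in place of amino on this chain carbon gives an at least 3.3-fold lower number from compound 1 to compound 3 (0.52 log units; beyond the scatter), and the other amino compound gives an at least 3.3-fold lower number from compound 2 to compound 3 (0.52 log units; beyond the scatter). Within the data shown here, these are the first steps at this position that can be read as beyond the scatter, whereas the step between the two amino compounds could not be read. Each gives only a minimum size, as the starting values are limits: the limit of > 100 ug/mL in this assay, at which 2 of the 3 values shown sit.

As far as these compounds go, how far the amino compounds truly lie above compound 3 remains open. So does where a carboxylic acid or a dimethylamino group on this carbon would fall.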